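Ester variation on the acetoxy(phenyl)methyl series

A few compounds are considered here, and "the series" means these few. Any claim that something is new, unique, unknown or untested is made for them only; others in the source may bear on it.

Measured so far:
compound 1 `O=C(CCCc1ccccc1)OC(CCN1CCN(CCCN(c2ccc(F)cc2)c2ccc(F)cc2)CC1)c1ccccc1` — 51.3 nM
compound 2 `CC(=O)OC(CCN1CCN(CCCN(c2ccc(F)cc2)c2ccc(F)cc2)CC1)c1ccccc1` — 4.28 nM

For the measured compounds named here, in an assay on membranes from striatum for displacement of a labelled ligand from sodium-dependent dopamine transporter (Rattus norvegicus) (on this read-out higher numbers stand for weaker inhibition and lower numbers for stronger inhibition), compound 2 gives 4.28 nM, the lowest of the two numbers so far; its nearest neighbour is compound 1, where the change of hydrogen in place of phenethyl on a saturated chain carbon bound to a carbonyl carbon gave a 12-fold lower number from compound 1 to compound 2 (1.08 log units; beyond the scatter).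

Compound 3 `C=CC(=O)OC(CCN1CCN(CCCN(c2ccc(F)cc2)c2ccc(F)cc2)CC1)c1ccccc1` is not yet measured. Its difference from compound 2 is vinyl in place of methyl on a carbonyl carbon. Going by the values given here, of the measured steps only the one from compound 1 to compound 2 bears on it, and that step was large, but it removed a far bigger group than the one added here; the present change swaps one heavy atom for two on the carbonyl carbon. The expected step is therefore small, a 1.4-fold higher number from compound 2 to compound 3 (0.15 log units; within the scatter), leaning toward a slightly higher number but within scatter. Compound 3 is estimated at 6 nM, range 2.5 nM to 15 nM.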

Compound 3, inhibition constant: 6.71 nM
Beside the measured number, compound 3's estimate is 1.1-fold (0.05 log units) below it; the range from low to high includes it.
By their numbers in this assay, from the lowest: compounds 2 and 3 (each within the scatter of the next); then compound 1.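

In this assay the change of methyl to vinyl on the carbonyl carbon gives a 1.6-fold higher number from compound 2 to compound 3 (0.20 log units; within the scatter) and so shows that this position accepts a double bond and one more heavy atom with no readable shift in the number. The change of 3-phenylpropyl to vinyl gives a 7.6-fold lower number from compound 1 to compound 3 (0.88 log units; beyond the scatter) and so shows that a second short group, not only methyl, stands well clear of the long chain in compound 1. No measurement shown here explains these numbers.

Going by these compounds, whether a chain of intermediate length, such as ethyl or propyl, reads like the short groups or like 3-phenylpropyl remains open. Also open, on these data alone, is how this carbonyl carbon responds to a group bearing an amine or a carboxylic acid.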